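A few compounds are considered here, and "the series" means these few. Any claim that something is new, unique, unknown or untested is made for them only; others in the source may bear on it.

Among the measured compounds shown here, in a functional assay on HEK293 cells for agonist activity at D(4) dopamine receptor (Homo sapiens), read by FLIPR (on this read-out higher numbers stand for an effect only at larger amounts of compound and lower numbers for an effect already at smaller amounts), compound 1 `CSc1cccc(NC(=O)CN2CCC(c3cccc[n+]3[O-])CC2)c1` gives 100 nM, the lowest of the three numbers so far. Compound 2 `CC(C)Oc1cccc(NC(=O)CN2CCC(c3cccc[n+]3[O-])CC2)c1` gives 555 nM and compound 3 `O=C(CN1CCC(c2cccc[n+]2[O-])CC1)Nc1cccc(-c2ccccc2)c1` gives 360 nM. The steps of a 5.6-fold higher number from compound 1 to compound 2 (0.74 log units; beyond the scatter) and a 3.6-fold higher number from compound 1 to compound 3 (0.56 log units; beyond the scatter) show that exchanging the methylsulfanyl group on the aromatic carbon has so far only raised the number, while a 1.5-fold lower number from compound 2 to compound 3 (0.19 log units; within the scatter). Compound 4 `O=C(CN1CCC(c2cccc[n+]2[O-])CC1)Nc1ccccc1F` differs from compound 1 by 2-fluorophenyl in place of 3-(methylsulfanyl)phenyl on an amide-type nitrogen. For the measured compounds named here, no measured step exchanges the whole ring substituent or introduces fluorine, so the two modest rises from compound 1 are the only guide, and a modest rise is expected here as well. For compound 4 the estimate is 350 nM, with a range from 120 nM to 1200 nM. The step expected is a 3.5-fold higher number from compound 1 to compound 4 (0.54 log units; beyond the scatter).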

Compound 4, half-maximal effective concentration: 270 nM
Compound 4: middle estimate off by 1.3-fold (0.11 log units), on the high side; the measured number falls inside the stated range.
By their numbers in this assay, from the lowest: compound 1; then compounds 4, 3 and 2 (each within the scatter of the next, the first and the last beyond it).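

Exchanging the whole 3-(methylsulfanyl)phenyl on the amide-type nitrogen for 2-fluorophenyl gives a 2.7-fold higher number from compound 1 to compound 4 (0.43 log units; beyond the scatter) in this assay. The number therefore also rises, by a modest step, when the entire aryl group changes, and not only when the methylsulfanyl group alone is exchanged. Nothing at hand accounts for this rise. On these data alone, the loss of methylsulfanyl and the entry of fluorine occur together here, so their separate contributions remain open. Also open, as far as these compounds go, is how an amine, a carboxylic acid or a longer chain on the phenyl ring would read in this assay.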